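Cutting the aryl amide of compound 2 down to a primary amide

The compounds below may be only part of what the source reports. "The series", "measured", "known", "first", "only" and "open" are said of these compounds alone.

Compound 2 `N#C/C(=C\c1cc(O)c(O)c([N+](=O)[O-])c1)C(=O)Nc1cccc(Cl)c1` is one of three close relatives built on a shared core. In a functional assay on KB cells (Homo sapiens) for antiproliferative activity, read by MTT assay (on this read-out lower numbers stand for stronger inhibition and higher numbers for weaker inhibition), compound 2 gives 72.7 ug/mL, the second highest of the three numbers, and its neighbours sit within the scatter on either side: compound 3 `COc1cc(/C=C(\C#N)C(=O)Nc2cccc(Cl)c2)cc([N+](=O)[O-])c1O` gives 56.6 ug/mL and compound 1 `N#C/C(=C\c1cc(O)c(O)c([N+](=O)[O-])c1)C(=O)N(c1ccccc1)c1ccccc1` gives 104 ug/mL. Within the data shown here, the one single-point step among them, a 1.3-fold lower number from compound 2 to compound 3 (0.11 log units; within the scatter), is within the scatter.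

Compound 4 `N#C/C(=C\c1cc(O)c(O)c([N+](=O)[O-])c1)C(N)=O` differs from compound 2 by hydrogen in place of 3-chlorophenyl on an amide-type nitrogen. Among the measured compounds shown here, no measured step touches the amide nitrogen, so the data give no direct guide; the only comparison that comes near is that compound 1, which carries two phenyl groups on that nitrogen, and compound 2 differ by less than the scatter. Given that, the step from compound 2 to compound 4 is expected to be small, a 1.4-fold higher number from compound 2 to compound 4 (0.14 log units; within the scatter), with a lean toward a higher number. Compound 4 is therefore estimated at 100 ug/mL, within a range of 40 ug/mL to 250 ug/mL.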

Compound 4, half-maximal inhibitory concentration: > 100 ug/mL
Compound 4 was reported as a limit; the forecaster's own chance of this, stated with the estimate: 10%; the middle value lies on the limit itself.
By their numbers in this assay, from the lowest: compounds 3, 2 and 1 (each within the scatter of the next).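

Compound 4 gives > 100 ug/mL in this assay, which is a limit of the assay and not a number. Among these compounds, this is the first single-point change at the amide-type nitrogen, and the step, an at least 1.3-fold higher number from compound 2 to compound 4 (0.13 log units; that floor lies within the scatter), is only a floor, so its true size cannot be read. Hydrogen in place of 3-chlorophenyl brings no measured gain here, but how far the primary amide lies from compound 2 stays unfixed: the limit of > 100 ug/mL in this assay, at which 1 of the 4 values shown sits.

From the compounds shown here alone, whether a methyl group or a longer chain on the amide-type nitrogen would give a readable number in this assay remains open. So does the outcome of a single unsubstituted phenyl on that nitrogen, or of a carboxylic acid in place of the chlorine of the 3-chlorophenyl group.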